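Triazole thioethers: propyl to trimethoxyphenyl on the core

The compounds below may be only part of what the source reports. "The series", "measured", "known", "first", "only" and "open" are said of these compounds alone.

Compound 3 `CCCc1nnc(SCC(=O)c2ccccc2)n1N1C(=O)c2ccccc2C1=O` carries a benzoyl on the saturated chain carbon bound to sulfur. In a functional assay on A549 cells (Homo sapiens) for cytotoxicity, read by MTT assay, with a stated time of 48 h (a higher number here means a weaker inhibitor, a lower number a stronger inhibitor), compound 3 gives only a limit, > 200000 nM. Compound 1 `C=CCSc1nnc(CCC)n1N1C(=O)c2ccccc2C1=O` likewise returns a limit in this assay, > 200000 nM. Compound 2 `CCCc1nnc(SCc2ccccc2)n1N1C(=O)c2ccccc2C1=O` also returns a limit in this assay, > 200000 nM. The steps among them, a step that the two limits leave unreadable from compound 1 to compound 2, a step that the two limits leave unreadable from compound 1 to compound 3 and a step that the two limits leave unreadable from compound 2 to compound 3, are therefore unreadable, as the limit of > 200000 nM in this assay, at which 3 of the 3 values shown sit, records. Compound 3 thus stands at the limit together with the other two, and no measured number sets it apart.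

Compound 4 `COc1cc(-c2nnc(SCC(=O)c3ccccc3)n2N2C(=O)c3ccccc3C2=O)cc(OC)c1OC` differs from compound 3 by 3,4,5-trimethoxyphenyl in place of propyl on an aromatic carbon. Going by the values given here, none of the measured steps concerns this position; all bear on the group on the saturated chain carbon bound to sulfur, and all are unreadable. Among the compounds with values here, no measured step gives a direction for this change in this assay. The expectation for compound 4 in this assay is a value near 100000 nM, ranging from 15000 nM to 300000 nM. The estimated step of an at least 2.0-fold lower number from compound 3 to compound 4 (0.30 log units; that floor lies within the scatter) is expected to be modest, with a fair chance that compound 4 again returns only a limit.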

Compound 4, half-maximal inhibitory concentration: > 200000 nM
Compound 4: only a limit was reported; the forecaster's own chance of this, stated with the estimate: 55%; middle value at least 2.0-fold (0.30 log units) away from the limit.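

In this assay compound 4 gives > 200000 nM, which is only a limit, so the step from compound 3 to compound 4 cannot be read. The compounds shown leave open whether either varied position on the shared core can produce a measurable cytotoxic value.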